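The source may hold more compounds than are shown below. What is called first, only, known or untested is meant among the compounds shown, and "the series" means these compounds.

Working notes on the series. Of the compounds shown here, two sharing the same core have been measured in an assay on C3H 10T1/2 cells for inhibition of Sonic hedgehog protein (Mus musculus), read by a luciferase reporter; a higher number here means a weaker inhibitor, a lower number a stronger inhibitor. Compound 1 `Cc1nc(C(F)(F)F)ccc1C(=O)Nc1ccc(Cl)c(-c2nc3ccccc3n2C)c1` gives 9 nM. Compound 2 `Cc1nc(C(F)(F)F)ccc1C(=O)Nc1ccc(Cl)c(C(=O)Nc2ccccc2)c1` gives 140 nM. Among the compounds with values here, compound 2 thus stands highest of the two numbers; the only step in hand is a 16-fold higher number from compound 1 to compound 2 (1.19 log units; beyond the scatter), which runs from compound 1 to compound 2 and is clearly beyond the scatter.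

The next compound, compound 3 `Cc1nc(C(F)(F)F)ccc1C(=O)Nc1ccc(Cl)c(-n2cccn2)c1`, differs from compound 2 by 1H-pyrazol-1-yl in place of phenylcarbamoyl on an aromatic carbon. Within the data shown here, no measured step covers this exact exchange. Among the measured compounds shown here, the one step that bears on it is a 16-fold higher number from compound 1 to compound 2 (1.19 log units; beyond the scatter), where a directly attached five-membered heteroaryl gave way to phenylcarbamoyl and the number rose sharply. Compound 3 reverses the direction of that step in kind, putting a directly attached five-membered heteroaryl back in place of the phenylcarbamoyl, though a smaller one than compound 1 carries. Part of the lost ground is therefore expected to be recovered, and a 4.7-fold lower number from compound 2 to compound 3 (0.67 log units; beyond the scatter) is the estimated step. For compound 3 the expected value in this assay is 30 nM, with a range of 8 nM to 120 nM.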

Compound 3, half-maximal inhibitory concentration: 450 nM
Compound 3: the middle estimate sits 15-fold (1.18 log units) below what was measured; the measured number lies above the stated range.
By their numbers in this assay, from the lowest: compound 1; then compound 2; then compound 3.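

At this position, ortho to a chloro group, a five-membered aromatic ring with 2 hetero atoms does not by itself keep the number low in this assay: replacing phenylcarbamoyl with 1H-pyrazol-1-yl gives a 3.2-fold higher number from compound 2 to compound 3 (0.51 log units; beyond the scatter), and replacing 1-methyl-1H-benzimidazol-2-yl with the same group gives a 50-fold higher number from compound 1 to compound 3 (1.70 log units; beyond the scatter). The earlier pair could be read as heteroaryl against phenylcarbamoyl, but that reading no longer holds, as phenylcarbamoyl now ranks between the two heteroaryl groups, with compound 1 the strongest and compound 3 the weakest of the three. No measurement in hand accounts for these differences.

The compounds shown do not separate what the fused benzene ring and the N-methyl group of 1-methyl-1H-benzimidazol-2-yl each contribute, which a 1H-benzimidazol-2-yl or a 1-methyl-1H-imidazol-2-yl group at the same position would address. They also leave open whether a six-membered heteroaryl such as pyridin-2-yl, or a phenylcarbamoyl analogue carrying a substituent on its phenyl ring, would match compound 1 or fall nearer compound 3.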